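The compounds below may be only part of what the source reports. "The series", "measured", "known", "first", "only" and "open" are said of these compounds alone.

Measured in a functional assay on ileum (Cavia porcellus) for inhibition; on this read-out lower numbers stand for stronger inhibition and higher numbers for weaker inhibition:
- Compound 1 `COC(=O)C1=C(C)NC(C)=C(C(=O)OC)C1c1c(-c2ccccn2)nc2sccn12`: 2570 nM
- Compound 2 `COC(=O)C1=C(C)NC(C)=C(C(=O)OC)C1c1c(-c2cccs2)nc2sccn12`: 110 nM
- Compound 3 `COC(=O)C1=C(C)NC(C)=C(C(=O)OC)C1c1c(-c2ccsc2)nc2sccn12`: 2.3 nM

The three compounds share one core and differ only in the aromatic ring on an aromatic carbon of that core. Compound 3 has the lowest number of the three, at 2.3 nM. Its nearest neighbour is reached by a 48-fold lower number from compound 2 to compound 3 (1.68 log units; beyond the scatter), and the furthest by a 1100-fold lower number from compound 1 to compound 3 (3.05 log units; beyond the scatter), both beyond the scatter.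

Compound 4 `COC(=O)C1=C(C)NC(C)=C(C(=O)OC)C1c1c(-c2c(Cl)csc2Cl)nc2sccn12` keeps the core and the thiophene ring but alters the group at the same place: a group of 7 heavy atoms (4 carbon, 1 sulfur, 2 chlorine; one five-membered aromatic ring with 1 hetero atom) in place of a group of 5 heavy atoms (4 carbon, 1 sulfur; one five-membered aromatic ring with 1 hetero atom), on an aromatic carbon.

Among the compounds with values here, no measured step adds chlorine, so the data give no direct measure of this change. The steps bear on it only indirectly. a 23-fold lower number from compound 1 to compound 2 (1.37 log units; beyond the scatter) shows how much this place responds to a change of ring, and a 48-fold lower number from compound 2 to compound 3 (1.68 log units; beyond the scatter) shows a large step between two thiophene isomers. A sizeable step is therefore expected here too. Since compound 3 already holds the lowest number at 2.3 nM, the expected direction is upward, though with much uncertainty. The expected change is an 8.7-fold higher number from compound 3 to compound 4 (0.94 log units; beyond the scatter). For compound 4 the estimate is 20 nM, with an expected range from 1.5 nM to 300 nM.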

Compound 4, half-maximal inhibitory concentration: 180 nM
Compound 4: the middle estimate sits 9.0-fold (0.95 log units) below what was measured, within the range that was stated.
By their numbers in this assay, from the lowest: compound 3; then compounds 2 and 4 (each within the scatter of the next); then compound 1.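

In this assay, placing two chlorine atoms on the thiophene ring gives back much of what compound 3 holds (a 78-fold higher number from compound 3 to compound 4 (1.89 log units; beyond the scatter)), so the low number depends on more than the presence of a thiophene ring at this place. The chlorine-bearing ring ends up level with thiophen-2-yl (a 1.6-fold higher number from compound 2 to compound 4 (0.21 log units; within the scatter)), a step within the scatter, yet it remains clearly better placed than pyridin-2-yl (a 14-fold lower number from compound 1 to compound 4 (1.15 log units; beyond the scatter)). The earlier compounds shown here showed that the choice of ring and the way it is attached both move the number, whereas this result shows that groups carried on the ring itself move it as well, and by a large step.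

No measurement offered here explains why the number rises with this change. Going by these compounds, it remains open whether a single chlorine atom, or a methyl group, a methoxy group or an amine on the thiophen-3-yl ring, would leave compound 3 near its 2.3 nM or would raise the number as far as the two chlorine atoms do.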